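Morpholin-4-yl for Thiomorpholin-4-yl: Two Cores Compared

This account rests on a few compounds, and the source may have more. Where it says the series, first, only, none or still open, it means among the compounds named here.

Of the compounds shown here, three have so far been tested in a functional assay on MCF7 cells (Homo sapiens) for cytotoxicity, read by MTT assay, with a stated time of 72 h, tested at 1 uM; a lower number here means less inhibition of growth, a higher number more inhibition of growth at the concentration tested. Compound 1 `Cc1ccnc(/C(N)=N/NC(=S)N2CCOCC2)c1` gives 1.22%, and compound 2 `Cc1ccnc(/C(N)=N/NC(=S)N2CCSCC2)c1` gives 3.89%. The two differ in one place, (morpholin-4-yl in place of thiomorpholin-4-yl on a thiocarbonyl carbon), and this change makes a step of a number 2.7 percentage points lower from compound 2 to compound 1 (within the scatter). Compound 3 `N/C(=N\NC(=S)N1CCSCC1)c1ccc(F)cn1` shows the highest number of the three in this assay, 30.6%, and its distance from compound 2 as well as from compound 1 lies beyond the scatter. How the core of compound 3 differs from that of compound 2 is not broken down here.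

Compound 4 `N/C(=N\NC(=S)N1CCOCC1)c1ccc(F)cn1` has not yet been measured in this assay. It is related to compound 3 by the same change that leads from compound 2 to compound 1: morpholin-4-yl in place of thiomorpholin-4-yl on a thiocarbonyl carbon. The step from compound 3 to compound 4 is expected to be small, about a number 2.6 percentage points lower from compound 3 to compound 4 (within the scatter), because the matching step a number 2.7 percentage points lower from compound 2 to compound 1 (within the scatter) lay within the scatter. As far as these compounds go, that expectation rests on a single measured pair, and compound 3 starts from a higher number on a core where the change is untested. Compound 4 is therefore estimated at 28%, with a likely range from 14% to 42%.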

Compound 4, percent growth inhibition at one concentration: 12.4%
The estimate for compound 4 lay 15.6 percentage points above the measured number, and the stated range ends above it.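

In this assay, morpholin-4-yl in place of thiomorpholin-4-yl on a thiocarbonyl carbon gives a step of a number 18.2 percentage points lower from compound 3 to compound 4 (beyond the scatter). Set beside the earlier step, the same change does not keep one size from one core to the other: the same change on two cores in this assay, a number 2.7 percentage points lower (within the scatter) from compound 2 to compound 1 and a number 18.2 percentage points lower (beyond the scatter) from compound 3 to compound 4, 15.5 percentage points apart, beyond the scatter of two such steps. The size of this step therefore depends on the core across these two matched pairs, so a step read on one of these cores would not have predicted the step on the other, but two pairs give no rule for any further core and do not show which feature of the cores sets the size.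

The compounds shown carry only thiomorpholin-4-yl or morpholin-4-yl on the thiocarbonyl carbon, so it remains open how a piperidin-1-yl group, a piperazin-1-yl group or a dimethylamino group would behave there on either core. As far as these compounds go, it also remains open whether the gap between the two steps would persist on a core carrying a chloro or methoxy group, or at other concentrations.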